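This account rests on a few compounds, and the source may have more. Where it says the series, first, only, none or still open, it means among the compounds named here.

Measured compounds:
- compound 1, `C[C@H](/C=C/C=C/C=C/[C@H](O)CC(=O)O)[C@@H](O)[C@H](C)C[C@@H](C)[C@H](O)CC(=O)c1ccc(N)cc1`, in a functional assay on HCT-116 cells (Homo sapiens) for cytotoxicity, read by sulforhodamine B assay, with a stated time of 72 h (a lower number here means a stronger inhibitor, a higher number a weaker inhibitor), compound 1 gives > 10000 nM, which is a limit of the assay
- compound 2, `CNc1ccc(C(=O)C[C@@H](O)[C@H](C)C[C@@H](C)[C@H](O)[C@H](C)/C=C/C=C/C=C/[C@H](O)CC(=O)O)cc1`, compound 2 gives > 10000 nM, a limit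
- compound 3, `CC(=O)Nc1ccc(C(=O)C[C@@H](O)[C@H](C)C[C@@H](C)[C@H](O)[C@H](C)/C=C/C=C/C=C/[C@H](O)CC(=O)O)cc1`, compound 3 gives > 10000 nM, a limit

Compound 3 therefore stands nowhere in particular among the numbers shown: its value is a limit, and so are the other two, all sitting at the limit of > 10000 nM in this assay, at which 3 of the 3 values shown sit. The three steps that could be compared, a step that the two limits leave unreadable from compound 1 to compound 2, a step that the two limits leave unreadable from compound 1 to compound 3 and a step that the two limits leave unreadable from compound 2 to compound 3, are all left unreadable by the limits, so none of them says how the substituent on the aromatic nitrogen moves cytotoxicity.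

Compound 4, `C[C@H](/C=C/C=C/C=C/[C@H](O)CC(=O)O)[C@@H](O)[C@H](C)C[C@@H](C)[C@H](O)CC(=O)c1ccc(N[C@@H]2O[C@H](CO)[C@@H](O)[C@H](O)[C@H]2O)cc1`, differs from compound 3 by 3,4,5-trihydroxy-6-(hydroxymethyl)oxan-2-yl in place of acetyl on a nitrogen on an aromatic ring. Among the measured compounds shown here, no measured step bears readably on this change. For the measured compounds named here, because every value so far rests at the limit of > 10000 nM in this assay, at which 3 of the 3 values shown sit, compound 4 is expected to remain at that limit as well, and the expected step is a step that the limit leaves unreadable from compound 3 to compound 4, meaning no change beyond the scatter. Compound 4 is thus estimated at 15000 nM, with a range from 5000 nM to 60000 nM.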

Compound 4, half-maximal inhibitory concentration: > 10000 nM
Compound 4: only a limit was reported (the forecaster's own chance of this, stated with the estimate: 85%); the middle value does not contradict the limit.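

In this assay compound 4 gives > 10000 nM, which is a limit of the assay. The steps to compound 4 from compound 1, compound 2 and compound 3 therefore cannot be read. The compounds shown leave open whether any substituent on the aromatic nitrogen changes cytotoxicity at all.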